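The source may report more compounds than this note shows. Statements on the series, on what has been measured and on what is new or still open speak of the compounds shown alone.

Measured so far, in a functional assay on MDA-MB-231 cells (Homo sapiens) for antiproliferative activity, read by CCK-8 assay, with a stated time of 72 h; on this read-out lower numbers stand for stronger inhibition and higher numbers for weaker inhibition:
compound 1 `COc1ccc(C(=O)Nc2cccc(-c3oc4cc(-c5ccc(F)cc5)ccc4c(=O)c3O)c2)cc1` gives 16500 nM;
compound 2 `Cc1ccc(C(=O)Nc2cccc(-c3oc4cc(-c5ccc(F)cc5)ccc4c(=O)c3O)c2)cc1` gives 4350 nM;
compound 3 `COc1ccccc1C(=O)Nc1cccc(-c2oc3cc(-c4ccc(F)cc4)ccc3c(=O)c2O)c1` gives 5110 nM.

Compound 2 has the lowest number of the three: its gap to compound 3 is within the scatter, whereas the gap to compound 1 is beyond it, as the step of a 3.8-fold lower number from compound 1 to compound 2 (0.58 log units; beyond the scatter) shows. The next compound, compound 4 `Cc1ccccc1C(=O)Nc1cccc(-c2oc3cc(-c4ccc(F)cc4)ccc3c(=O)c2O)c1`, has not yet been measured in this assay. It differs from compound 2 by 2-methylphenyl in place of 4-methylphenyl on a carbonyl carbon. The closest guide is the same kind of rearrangement within the methoxy pair, a 3.2-fold lower number from compound 1 to compound 3 (0.51 log units; beyond the scatter), a modest gain beyond the scatter. The step of a 1.2-fold higher number from compound 2 to compound 3 (0.07 log units; within the scatter) adds that the two shapes of amide cap can land close together. From compound 2 to compound 4 the change is therefore expected to be a 1.5-fold lower number from compound 2 to compound 4 (0.16 log units; within the scatter), small and uncertain in direction. For compound 4 the estimate in this assay is 3000 nM, ranging from 1200 nM to 8000 nM.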

Compound 4, half-maximal inhibitory concentration: 4910 nM
Compound 4: middle estimate off by 1.6-fold (0.21 log units), on the low side; low and high end bracket the measured number.
By their numbers in this assay, from the lowest: compounds 2, 4 and 3 (each within the scatter of the next); then compound 1.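

Replacing 4-methylphenyl with 2-methylphenyl on the carbonyl carbon gives a 1.1-fold higher number from compound 2 to compound 4 (0.05 log units; within the scatter), so in this assay the two methyl arrangements cannot be told apart. Methyl in place of methoxy on the 2-substituted phenyl gives a 1.0-fold lower number from compound 3 to compound 4 (0.02 log units; within the scatter), while 4-methoxyphenyl stands apart, with a 3.4-fold lower number from compound 1 to compound 4 (0.53 log units; beyond the scatter). The effect of methyl in place of methoxy therefore depends on the compound pair in which it is made: the same change on two cores in this assay, a 3.8-fold lower number (0.58 log units; beyond the scatter) from compound 1 to compound 2 and a 1.0-fold lower number (0.02 log units; within the scatter) from compound 3 to compound 4, 3.6-fold (0.56 log units) apart, beyond the scatter of two such steps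

On these data alone, it remains open whether a chlorine or a hydroxyl on this phenyl would match the methyl compounds or compound 1.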